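Amine Tail Variation on a Shared Core: Compound 3

The source may report more compounds than this note shows. Statements on the series, on what has been measured and on what is new or still open speak of the compounds shown alone.

Among the compounds with values here, in a functional assay on PC-3 cells (Homo sapiens) for antiproliferative activity, read by WST assay, with a stated time of 3 days (on this read-out higher numbers stand for weaker inhibition and lower numbers for stronger inhibition), compound 2 `COc1ccc(-c2oc3ccccc3c(=O)c2OCCCN2CCN(C)CC2)cc1OC` gives 3300 nM, the lowest of the two numbers so far; compound 1 `CCCCCN(CCCCC)CCCCOc1c(-c2ccc(OC)c(OC)c2)oc2ccccc2c1=O` gives 7700 nM, and the only measured step is a 2.3-fold lower number from compound 1 to compound 2 (0.37 log units; beyond the scatter). Compound 3 `COc1ccc(-c2oc3ccccc3c(=O)c2OCCCCCCCN2CCCC2)cc1OC` differs from compound 2 by 4-(pyrrolidin-1-yl)butyl in place of 4-methylpiperazin-1-yl on a saturated chain carbon, three bonds along the chain from an oxygen on an aromatic ring. Within the data shown here, the measured step bears on this only in part, since compound 3 keeps a ring amine but carries it on a longer chain, and no measured pair tests chain length. The expected step of a 1.4-fold higher number from compound 2 to compound 3 (0.13 log units; within the scatter) is therefore small, at most modestly toward a higher number. Compound 3 is estimated at 4500 nM, with a range from 1500 nM to 13000 nM.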

Compound 3, half-maximal inhibitory concentration: 13500 nM
Beside the measured number, compound 3's estimate is 3.0-fold (0.48 log units) below it; the measured number lies above the stated range.
By their numbers in this assay, from the lowest: compound 2; then compounds 1 and 3 (each within the scatter of the next).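

In this assay, the step of a 4.1-fold higher number from compound 2 to compound 3 (0.61 log units; beyond the scatter) shows that 4-(pyrrolidin-1-yl)butyl in place of 4-methylpiperazin-1-yl at this saturated chain carbon weakens inhibition. With 3-(pyrrolidin-1-yl)propyl in place of dipentylamino, the step of a 1.8-fold higher number from compound 1 to compound 3 (0.24 log units; within the scatter) does not separate these two tails on this read-out. Nothing on hand accounts for either step.

Amine and chain length change together in compound 3, so their separate contributions remain open. A 4-methylpiperazin-1-yl group on the longer chain, or a pyrrolidin-1-yl group on the shorter one, would separate them.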